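Working notes on urea permeability: compound 1 to compound 4

The source may hold more compounds than are shown below. What is called first, only, known or untested is meant among the compounds shown, and "the series" means these compounds.

Measured so far:
compound 1, `CCc1ccc(NC(=O)Nc2cc(C)nc3ccccc23)cc1`, 535 10^-6 cm/s
compound 2, `Cc1cc(NC(=O)Nc2cccc(C(N)=O)c2)c2ccccc2n1`, 2 10^-6 cm/s
compound 3, `Cc1cc(NC(=O)Nc2ccc3[nH]cnc3c2)c2ccccc2n1`, 2 10^-6 cm/s

In an ADME assay for permeability, using PAMPA, at pH 7.4 (on this read-out higher numbers stand for higher permeability and lower numbers for lower permeability), compound 1 stands highest of the three numbers; compound 2 and compound 3 each sit far lower, beyond the scatter. Within the data shown here, no two of these measured compounds differ in one place, so no measured single-point step exists. Compound 4 `Cc1cc(NC(=O)Nc2ccc(OC(F)(F)F)cc2)c2ccccc2n1` differs from compound 1 by trifluoromethoxy in place of ethyl on an aromatic carbon. Because compound 1 already gives 535 10^-6 cm/s, compound 4 is expected to stay in the same high region. The step of a 1.3-fold lower number from compound 1 to compound 4 (0.13 log units; within the scatter) is estimated to be small, at most a modest decrease, likely within the scatter. Compound 4 is expected to give 400 10^-6 cm/s, with a range from 150 10^-6 cm/s to 800 10^-6 cm/s.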

Compound 4, apparent permeability: 531 10^-6 cm/s
The estimate for compound 4 lay 1.3-fold (0.12 log units) below the measured number; the range from low to high includes it.
By their numbers in this assay, from the lowest: compounds 2 and 3 (each within the scatter of the next); then compounds 4 and 1 (each within the scatter of the next).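

Trifluoromethoxy in place of ethyl on an aromatic carbon, para to a large group, gives in this assay a 1.0-fold lower number from compound 1 to compound 4 (0.00 log units; within the scatter) and forms the first single-place step in the series. At this position, the two groups therefore stand level on this read-out, despite the larger heavy-atom count of trifluoromethoxy. Nothing measured on either group bears on this result. As far as these compounds go, an amine or a carboxylic acid at this position remains open, as does a chain longer than ethyl. Whether the level outcome holds for such groups cannot be read from this single step.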